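The compounds below may be only part of what the source reports. "The series", "measured", "known", "first", "only" and "open" are said of these compounds alone.

Compound 2 `CNCc1cc(-c2cccnc2C#N)n(S(=O)(=O)c2cccnc2)c1` gives 48% in a functional assay on the whole organism (strain Jcl:SD) for inhibition, with Rattus norvegicus as the target, with stated times of 3 min and 3 h, at a dose of 1 mg/kg by the intravenous route (on this read-out lower numbers stand for less inhibition and higher numbers for more inhibition at the one dose given (going by the name of the read-out)), the lower of the two numbers recorded so far; compound 1 `CNCc1cc(-c2cccnc2F)n(S(=O)(=O)c2cccnc2)c1` gives 96%. Compound 3 `CNCc1cc(-c2ncccc2C)n(S(=O)(=O)c2cccnc2)c1` has not been measured. It differs from compound 2 by 3-methylpyridin-2-yl in place of 2-cyanopyridin-3-yl on an aromatic carbon. Among the compounds with values here, the only measured step, a number 48 percentage points lower from compound 1 to compound 2 (beyond the scatter), also concerned the pyridyl group on the shared core, and the cyano group it introduced is now removed, so a rise is expected, though the different ring attachment leaves its size uncertain. The expected step is a number 22 percentage points higher from compound 2 to compound 3 (beyond the scatter). Compound 3 is therefore estimated at 70%, between 35% and 95%.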

Compound 3, a percentage reported as inhibition, in the whole organism at one dose (the size of the read-out at that dose, not a potency): 5%
Estimate against measurement, compound 3: 65 percentage points above, and the stated range ends above it.
By their numbers in this assay, from the lowest: compound 3; then compound 2; then compound 1.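

In this assay, the group on this ring carbon can take the effect almost to nothing: a number 43 percentage points lower from compound 2 to compound 3 (beyond the scatter), and a number 91 percentage points lower from compound 1 to compound 3 (beyond the scatter). Losing the nitrile therefore does not by itself bring the number back, and 2-fluoropyridin-3-yl, 2-cyanopyridin-3-yl and 3-methylpyridin-2-yl differ widely here. Nothing available gives a reason for this drop. Still open, on these data alone, is whether the loss goes with the methyl group or with the way the pyridine ring is attached. A 2-methylpyridin-3-yl group would separate these two, and a 2-aminopyridin-3-yl group would extend the comparison with fluoro and nitrile.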